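A few compounds are considered here, and "the series" means these few. Any claim that something is new, unique, unknown or untested is made for them only; others in the source may bear on it.

In a functional assay on A549 cells (Homo sapiens) for inhibition, read by sulforhodamine B assay, with a stated time of 48 h (a higher number here means that more compound is tolerated, a lower number that less compound is tolerated), compound 3 `COc1ccc(Sc2nc3cc(N)cc(N)c3nc2-c2ccccc2)cc1` gives only a limit, < 100000 nM. Compound 1 `Nc1cc(N)c2nc(-c3ccccc3)c(Oc3ccc(Cl)c(Cl)c3)nc2c1` likewise gives only a limit in this assay, < 100000 nM. Compound 2 `Nc1cc(N)c2nc(-c3ccccc3)c(NCc3ccc(F)cc3)nc2c1` gives a number in this assay, 69200 nM. The steps a step that the limit leaves unreadable from compound 1 to compound 2, a step that the two limits leave unreadable from compound 1 to compound 3 and a step that the limit leaves unreadable from compound 2 to compound 3 cannot be sized because of the limit of < 100000 nM in this assay, at which 2 of the 3 values shown sit. Compound 4 `Nc1cc(N)c2nc(-c3ccccc3)c(Sc3ccc(Cl)c(Cl)c3)nc2c1` has not been measured; it differs from compound 3 by 3,4-dichlorophenyl in place of 4-methoxyphenyl on a sulfur. Going by the values given here, no measured step swaps this group on a sulfur, and the limits hide the size of every comparable change, so compound 4 is expected to stay close to compound 3, with a step that the limit leaves unreadable from compound 3 to compound 4 expected to lie within the scatter. The estimate for compound 4 in this assay is 70000 nM, between 25000 nM and 150000 nM.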

Compound 4, concentration lethal to 50% of the cells: < 100000 nM
Compound 4: a limit, no number; the forecaster's own chance of this, stated with the estimate: 50%; the middle value lies beyond the limit too.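

Compound 4 gives only a limit, so no step linking it to compound 1, compound 2 or compound 3 can be sized, and the reason is this: the limit of < 100000 nM in this assay, at which 3 of the 4 values shown sit. As far as these compounds go, whether 3,4-dichlorophenyl or 4-methoxyphenyl on the sulfur gives the lower value in this assay stays open.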